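Moving the hydroxyl group on a pyridine-linked biaryl scaffold

The source may report more compounds than this note shows. Statements on the series, on what has been measured and on what is new or still open speak of the compounds shown alone.

Measured compounds:
compound 1, `Oc1cccc(-c2cc(-c3ccncc3)nc(-c3cccc(Cl)c3)c2)c1`: 0%
compound 2, `Oc1ccc(-c2cc(-c3cccc(Cl)c3)nc(-c3ccccn3)c2)cc1`: 59.4%

In an assay on isolated protein for inhibition of DNA topoisomerase 1 (Homo sapiens), with a stated time of 30 min, tested at 100 uM (a lower number here means a weaker effect, a higher number a stronger effect of the compound at the concentration tested), compound 2 gives the higher of the two numbers; compound 1 lies well below it, beyond the scatter. Compound 3, `Oc1cccc(-c2cc(-c3cccc(Cl)c3)nc(-c3ccccn3)c2)c1`, has not yet been measured. It differs from compound 2 in one place: 3-hydroxyphenyl in place of 4-hydroxyphenyl on an aromatic carbon. Compound 1 also carries a 3-hydroxyphenyl group, yet its other aromatic substituent differs too, so the two measured values give no clean guide. The move from compound 2 to compound 3 is expected to lower inhibition, a number 24.4 percentage points lower from compound 2 to compound 3 (beyond the scatter), with wide uncertainty. Compound 3 is estimated at 35%, between 5% and 65%.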

Compound 3, a percentage reported as inhibition, at one concentration (the size of the read-out at that concentration, not a potency): 0.4%
Beside the measured number, compound 3's estimate is 34.6 percentage points above it, and the stated range ends above it.
By their numbers in this assay, from the lowest: compounds 1 and 3 (each within the scatter of the next); then compound 2.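

In this assay, the place of the hydroxyl group alone decides much of the inhibition: 3-hydroxyphenyl in place of 4-hydroxyphenyl gives a number 59 percentage points lower from compound 2 to compound 3 (beyond the scatter). With 3-hydroxyphenyl present, pyridin-2-yl in place of pyridin-4-yl gives a number 0.4 percentage points higher from compound 1 to compound 3 (within the scatter), so this change shows no readable effect in that setting. Nothing available explains why the hydroxyl's place matters so much. On these data alone, it remains open whether pyridin-4-yl would behave the same alongside 4-hydroxyphenyl, and whether 4-methoxyphenyl or 4-aminophenyl could stand in for 4-hydroxyphenyl.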